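A Chloro Group Tried on a Weakly Cytotoxic Hydrazone

A few compounds are considered here, and "the series" means these few. Any claim that something is new, unique, unknown or untested is made for them only; others in the source may bear on it.

Three compounds have been measured in a functional assay on HepG2 cells (Homo sapiens) for cytotoxicity, with a stated time of 24 h; a higher number here means a weaker inhibitor, a lower number a stronger inhibitor:

compound 1 `O=C(N/N=C/c1cc(I)c(O)c(I)c1)c1ccccc1` gives 191000 nM
compound 2 `Cc1ccc(C(=O)N/N=C/c2cc(I)c(O)c(I)c2)cc1` gives > 100000 nM, which is a limit of the assay, not a number
compound 3 `O=C(N/N=C/c1cc(I)c(O)c(I)c1)c1ccc(O)cc1` gives 110000 nM

Compound 3 holds the smaller of the two numbers in this assay, but the step of a 1.7-fold lower number from compound 1 to compound 3 (0.24 log units; within the scatter) places it and compound 1 within the scatter of each other. The third value, that of compound 2, is a limit, (the limit of > 100000 nM in this assay, at which 1 of the 3 values shown sits).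

Compound 4 `O=C(N/N=C/c1cc(I)c(O)c(I)c1)c1ccc(Cl)cc1` differs from compound 3 by chloro in place of hydroxy on an aromatic carbon. The steps that touch this change are a 1.7-fold lower number from compound 1 to compound 3 (0.24 log units; within the scatter), the step that the limit leaves unreadable from compound 1 to compound 2 and the step that the limit leaves unreadable from compound 2 to compound 3. Only the first is readable, and it is small; the other two run into the limit, so the methyl analogue, compound 2, may sit anywhere from near compound 1 upward.

Because the hydroxy analogue compound 3 and the unsubstituted compound 1 differ by a 1.7-fold lower number from compound 1 to compound 3 (0.24 log units; within the scatter), compound 4 is expected to give 180000 nM, between 60000 nM and 500000 nM, a step of a 1.6-fold higher number from compound 3 to compound 4 (0.21 log units; within the scatter), with a fair chance that the assay reports only a limit.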

Compound 4, half-maximal inhibitory concentration: > 100000 nM
Compound 4 ended at the assay's limit (the forecaster's own chance of this, stated with the estimate: 40%); the middle value lies beyond the limit too.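

In this assay compound 4 gives > 100000 nM and this is a limit, not a number. Within the data shown here, its steps to compound 1, compound 2 and compound 3 cannot be read, so this result adds no new step. The compounds shown leave open how compound 4 truly compares with compound 3, and whether chloro in place of hydroxy changes the reading at all.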